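This account rests on a few compounds, and the source may have more. Where it says the series, first, only, none or still open, it means among the compounds named here.

Three compounds that share one core have been tested in a functional assay on the whole organism (strain Swiss albino) with Mus musculus as the target, in the maximal electroshock model, with a stated time of 4 h; on this read-out lower numbers stand for an effect already at smaller amounts and higher numbers for an effect only at larger amounts of compound:

compound 1, `O=C(N/N=C/c1ccc(Br)cc1)Nc1cccc2ccccc12`, 300 mg/kg
compound 2, `CN(C)c1ccc(/C=N/NC(=O)Nc2cccc3ccccc23)cc1`, 100 mg/kg
compound 3, `O=C(N/N=C/c1ccccc1[N+](=O)[O-])Nc1cccc2ccccc12`, 300 mg/kg

Compound 1 sits at the same number as compound 3 at the digits shown, and the two together give the highest numbers of the three, so an effect appears only at larger amounts of either. Within the data shown here, the single step among the measured compounds, a 3.0-fold lower number from compound 1 to compound 2 (0.48 log units; beyond the scatter), comes from dimethylamino in place of bromo on an aromatic carbon. Compound 4, `O=C(N/N=C/c1ccc(Cl)cc1Cl)Nc1cccc2ccccc12`, has not yet been measured. It differs from compound 1 in one place: 2,4-dichlorophenyl in place of 4-bromophenyl on a carbon with a double bond to nitrogen. This keeps halogens on that ring and changes only which halogen and how many, so the measured step, which swaps a halogen for a quite different group, does not speak to it directly. Compound 3 bears a nitro group rather than bromo and gives 300 mg/kg, the same number as compound 1 at the digits shown, which hints that the group on this ring may matter little here. For compound 4 the expected step is therefore no change at the digits printed from compound 1 to compound 4 (within the scatter), within the scatter. Compound 4 is estimated at 300 mg/kg, ranging from 100 mg/kg to 600 mg/kg.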

Compound 4, minimum effective dose: 100 mg/kg
Beside the measured number, compound 4's estimate is 3.0-fold (0.48 log units) above it; the range from low to high includes it.
By their numbers in this assay, from the lowest: compounds 2 and 4 (each within the scatter of the next); then compounds 1 and 3 (each within the scatter of the next).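

In this assay, 2,4-dichlorophenyl in place of 4-bromophenyl on a carbon with a double bond to nitrogen gives a 3.0-fold lower number from compound 1 to compound 4 (0.48 log units; beyond the scatter), which shows that the number at this position can move even when halogens stay on the ring and dimethylamino is not involved. Compound 2, with its dimethylamino group, gives 100 mg/kg and compound 4 gives 100 mg/kg, so two very different groups at this position reach the same number at the digits printed, while compound 3, with its nitro group, stays level with compound 1. No measurement at hand explains why the halogen change lowers the number.

This single step changes both which halogen is present and how many there are, so a compound with 4-chlorophenyl or 2-chlorophenyl at this position would be needed to tell the two changes apart. Also open, on these data alone, is how groups of another kind at this position, such as methoxy or a carboxylic acid, would compare, and whether any of them would give a number lower than those of compound 2 and compound 4.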